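The source may report more compounds than this note shows. Statements on the series, on what has been measured and on what is new or still open speak of the compounds shown alone.

Three compounds built on one shared core have been run through an ADME assay on Vero cells (Chlorocebus sabaeus) for cytotoxicity; on this read-out lower numbers stand for higher toxicity in this test and higher numbers for lower toxicity in this test. Compound 1 `O=C(Nc1ccccc1F)c1cccc2[nH]c(-c3ccccn3)nc12` gives 54.7 uM, compound 2 `O=C(Nc1ccccc1F)c1cccc2[nH]c(-c3cccnc3)nc12` gives 54.7 uM, and compound 3 `O=C(Nc1ccccc1F)c1cccc2[nH]c(-c3ccncc3)nc12` gives 111 uM. Compound 3 holds the highest number of the three: a 2.0-fold higher number from compound 1 to compound 3 (0.31 log units; beyond the scatter) and a 2.0-fold higher number from compound 2 to compound 3 (0.31 log units; beyond the scatter), both beyond the scatter, whereas no change at the digits printed from compound 1 to compound 2 (within the scatter). Compound 4 `O=C(Nc1ccccc1F)c1cccc2[nH]c(-c3ccco3)nc12` differs from compound 3 in one place: furan-2-yl in place of pyridin-4-yl on an aromatic carbon. Among the measured compounds shown here, no measured step exchanges a six-membered ring for a five-membered one, so only the three pyridine swaps bear on it, and they were modest or within the scatter. On that basis the reviewer expects a 1.6-fold lower number from compound 3 to compound 4 (0.20 log units; within the scatter), with a drift toward the lower two values more likely than a further rise. Compound 4 is therefore estimated at 70 uM, between 30 uM and 160 uM.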

Compound 4, half-maximal toxic concentration: 25 uM
Compound 4: the middle estimate sits 2.8-fold (0.45 log units) above what was measured; measured number outside the range, below it.
By their numbers in this assay, from the lowest: compound 4; then compounds 1 and 2 (each within the scatter of the next); then compound 3.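

Placed on the aromatic carbon between two ring nitrogen atoms, furan-2-yl brings a 4.4-fold lower number from compound 3 to compound 4 (0.65 log units; beyond the scatter) in this assay as the largest step seen so far, along with a 2.2-fold lower number from compound 2 to compound 4 (0.34 log units; beyond the scatter) and a 2.2-fold lower number from compound 1 to compound 4 (0.34 log units; beyond the scatter) in the same direction. Compound 4 therefore has the lowest number of the four, so this position responds to more than the place of the pyridine nitrogen. Nothing available explains this result. As far as these compounds go, whether the fall follows the smaller ring or its oxygen stays open, and thiophen-2-yl or phenyl at this carbon would help separate the two.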